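Pyrimidin-5-yl in place of pyridin-4-yl

The compounds below may be only part of what the source reports. "The series", "measured", "known", "first", "only" and "open" are said of these compounds alone.

Within the data shown here, compound 1 `CCN(c1ccc(C#N)c(Cl)c1)c1cc(-c2ccncc2)ccc1C` stands at 2900 nM in a functional assay on VCaP cells (Homo sapiens) for antiproliferative activity, read by CCK-8 assay, with a stated time of 6 days (on this read-out lower numbers stand for stronger inhibition and higher numbers for weaker inhibition), as the lower of the two numbers so far. Compound 3 `CCN(c1ccc(C#N)c(Cl)c1)c1cc(-c2cnc3ccccc3c2)ccc1C` gives 25300 nM in this assay and lies beyond the scatter from compound 1. In this assay compound 2 `N#Cc1ccc(N2CCc3cc(-c4cccnc4)ccc32)cc1C(F)(F)F` is entered as "not determined" (no result reported). Compound 4 `CCN(c1ccc(C#N)c(Cl)c1)c1cc(-c2cncnc2)ccc1C` carries pyrimidin-5-yl in place of pyridin-4-yl on an aromatic carbon. Among the measured compounds shown here, no measured step covers this change, so the expectation stays near compound 1 at 2900 nM with a shift toward a higher number. The expected size is modest and little beyond the scatter (a 2.2-fold higher number from compound 1 to compound 4 (0.35 log units; beyond the scatter)). In this assay compound 4 is estimated at 6500 nM with an expected range of 2000 nM to 20000 nM as the working figure.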

Compound 4, half-maximal inhibitory concentration: 3920 nM
For compound 4 the middle estimate is 1.7-fold (0.22 log units) above the measured one; the range from low to high includes it.
By their numbers in this assay, from the lowest: compounds 1 and 4 (each within the scatter of the next); then compound 3.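

At this aromatic carbon, para to a methyl group, pyrimidin-5-yl in place of pyridin-4-yl gives a 1.4-fold higher number from compound 1 to compound 4 (0.13 log units; within the scatter) in this assay. A second hetero atom in the six-membered aromatic ring therefore yields a compound that this read-out cannot separate from compound 1. No measurement at hand accounts for this outcome.

As far as these compounds go, how an amine or a carboxylic acid on this aromatic carbon would compare with either ring stays open. Also open, from the compounds shown here alone, is whether pyrimidin-5-yl gives a similar result on the core of compound 2.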